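A Fluoro-for-Methyl Swap on the Triazole Aryl Ring

A few compounds are considered here, and "the series" means these few. Any claim that something is new, unique, unknown or untested is made for them only; others in the source may bear on it.

Measured compounds:
compound 1 `Cc1cccc(-n2cc(COc3cccc(NC(=O)Nc4ccc(Cl)c(C(F)(F)F)c4)c3)nn2)c1` — 7270 nM
compound 2 `CC(C)c1ccc(-n2cc(COc3cccc(NC(=O)Nc4ccc(Cl)c(C(F)(F)F)c4)c3)nn2)cc1` — 2470 nM

Two compounds sharing the same diaryl urea and triazole core have been measured in a functional assay on HepG2 cells (Homo sapiens) for inhibition, read by MTT assay, with a stated time of 72 h; on this read-out lower numbers stand for stronger inhibition and higher numbers for weaker inhibition. Compound 1 gives 7270 nM and stands as the highest of the two numbers; its nearest neighbour is compound 2, and the step of a 2.9-fold lower number from compound 1 to compound 2 (0.47 log units; beyond the scatter) comes from putting 4-isopropylphenyl in place of 3-methylphenyl on the aromatic nitrogen.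

Compound 3 `O=C(Nc1cccc(OCc2cn(-c3cccc(F)c3)nn2)c1)Nc1ccc(Cl)c(C(F)(F)F)c1` has not yet been measured in this assay. It differs from compound 1 by fluoro in place of methyl on an aromatic carbon. Among the measured compounds shown here, the one measured step, a 2.9-fold lower number from compound 1 to compound 2 (0.47 log units; beyond the scatter), concerns a different group on a different part of the phenyl ring, so it offers no direct guide to a change of this kind. With nothing in the data pointing either way, the step of a 1.0-fold lower number from compound 1 to compound 3 (0.02 log units; within the scatter) is expected to stay within the scatter of repeated measurements. Compound 3 is therefore estimated at 7000 nM in this assay, with a range from 3000 nM to 18000 nM.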

Compound 3, half-maximal inhibitory concentration: 2120 nM
Compound 3: the middle estimate sits 3.3-fold (0.52 log units) above what was measured; the measured number lies below the stated range.
By their numbers in this assay, from the lowest: compounds 3 and 2 (each within the scatter of the next); then compound 1.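

In this assay the change from 3-methylphenyl to 3-fluorophenyl gives a 3.4-fold lower number from compound 1 to compound 3 (0.54 log units; beyond the scatter) and so shows that this position responds to the exchange of one heavy atom for another. The earlier step had changed both the group and its place on the ring, whereas here the place stays the same and only methyl gives way to fluoro. The comparison with the 4-isopropylphenyl group gives a 1.2-fold lower number from compound 2 to compound 3 (0.07 log units; within the scatter) and so these two different aryl groups cannot be told apart on this read-out, even though each stands apart from the 3-methylphenyl group of compound 1.

No measured evidence accounts for the difference between fluoro and methyl at this position. On these data alone, it remains open whether chloro, methoxy or an amine in the same place would give a number closer to that of compound 1 or to that of compound 3, and whether a 4-fluorophenyl group would match the 3-fluorophenyl group of compound 3.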